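Working notes: hydroxy for methoxy, step from compound 2

A few compounds are considered here, and "the series" means these few. Any claim that something is new, unique, unknown or untested is made for them only; others in the source may bear on it.

Measured so far:
compound 1 `O=C(Nc1cccc(-n2cc(-c3ccncc3)c(-c3ccc(Cl)c(O)c3)n2)c1)Nc1cccc(C(F)(F)F)c1` in a functional assay on HOP-62 cells (Homo sapiens) for inhibition, read by sulforhodamine B assay, with a stated time of 48 h (a lower number here means a stronger inhibitor of growth, a higher number a weaker inhibitor of growth), gives 6860 nM
compound 2 `COc1cc(-c2nn(-c3cccc(NC(=O)Nc4cc(C(F)(F)F)cc(C(F)(F)F)c4)c3)cc2-c2ccncc2)ccc1Cl` in this assay gives 855 nM

Among the measured compounds shown here, compound 2 has the lower of the two numbers; compound 1 is the only neighbour and sits well beyond the scatter above it. The two compounds differ in two places at once, so the values alone do not tell which of the two changes carries the gap.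

Compound 3 `O=C(Nc1cccc(-n2cc(-c3ccncc3)c(-c3ccc(Cl)c(O)c3)n2)c1)Nc1cc(C(F)(F)F)cc(C(F)(F)F)c1` is not yet measured. It differs from compound 2 by hydrogen in place of methyl on an oxygen on an aromatic ring, that is methoxy to hydroxy, 4-chloro-3-methoxyphenyl to 4-chloro-3-hydroxyphenyl. The rest is kept: the urea with the bis-trifluoromethyl-substituted phenyl stays as in compound 2. For the measured compounds named here, compound 3 therefore shares the hydroxy group with compound 1 and the urea half with compound 2, and no single-change step between measured compounds is available to guide the size of the move.

The expectation for compound 3 is a number between the two measured ones, drifting toward compound 1 by a modest step, a 2.3-fold higher number from compound 2 to compound 3 (0.37 log units; beyond the scatter), weaker than compound 2 but not beyond the full gap to compound 1. The estimate for compound 3 is 2000 nM, with a range from 600 nM to 7000 nM.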

Compound 3, concentration for 50% growth inhibition: 964 nM
Estimate against measurement, compound 3: 2.1-fold (0.32 log units) above, and the stated range covers the measured number.
By their numbers in this assay, from the lowest: compounds 2 and 3 (each within the scatter of the next); then compound 1.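

In this assay, methoxy to hydroxy on the 4-chloro-3-methoxyphenyl group, with the urea half kept, gives a 1.1-fold higher number from compound 2 to compound 3 (0.05 log units; within the scatter), so at this oxygen on an aromatic ring this read-out does not separate methyl from hydrogen in the setting of the bis-trifluoromethyl-substituted phenyl urea. With the hydroxy group held, trifluoromethyl in place of hydrogen on an aromatic carbon gives a 7.1-fold lower number from compound 1 to compound 3 (0.85 log units; beyond the scatter), a single-change step that the two earlier compounds, differing in two places at once, could not provide. The series now holds one change at this oxygen that leaves the number within the scatter and one change on the urea phenyl ring that moves it beyond the scatter, each seen once. No measurement in hand bears on why either step has the size it has.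

From the compounds shown here alone, whether methoxy and hydroxy also stay within the scatter of each other with only one trifluoromethyl on the urea phenyl ring remains open, since that step is read only in the bis-trifluoromethyl setting. Also open, going by these compounds, is how an amine, a carboxylic acid or a longer chain such as ethoxy would read at the place of the hydroxy group.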